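The source may report more compounds than this note shows. Statements on the series, on what has been measured and on what is new or still open speak of the compounds shown alone.

Measured so far in a functional assay on MDA-MB-468 cells (Homo sapiens) for antiproliferative activity, read by MTT assay, with a stated time of 72 h; on this read-out higher numbers stand for weaker inhibition and lower numbers for stronger inhibition:
compound 1 `O=C(Nc1ccc(Cl)c(-c2nnc3c(Cl)cccn23)c1)c1ccc(Cl)cc1Cl`: 21600 nM
compound 2 `O=C(Nc1ccc(Cl)c(-c2nnc3c(Cl)cccn23)c1)c1cccnc1Cl`: a limit of this assay, > 100000 nM

Compound 2 stands only at a limit, not at a number; of the two values shown it sits at the limit of > 100000 nM in this assay, at which 1 of the 2 values shown sits. Among the measured compounds shown here, the single measured step, an at least 4.6-fold higher number from compound 1 to compound 2 (0.66 log units; beyond the scatter), put the 2-chloropyridin-3-yl amide at least modestly weaker than the 2,4-dichlorophenyl amide. Compound 3 `CS(=O)(=O)c1cccc(C(=O)Nc2ccc(Cl)c(-c3nnc4c(Cl)cccn34)c2)c1` alters the same position again: 3-(methylsulfonyl)phenyl in place of 2-chloropyridin-3-yl on a carbonyl carbon. For the measured compounds named here, no measured step runs from 2-chloropyridin-3-yl to 3-(methylsulfonyl)phenyl, so the step from compound 1 to compound 2 bears on it only by showing how much this position can move. Compound 2 gives a limit; a lower number for compound 3 is therefore the only movement that could be seen, and a return toward the value of compound 1 is not ruled out. For compound 3 the expectation is 60000 nM (15000 nM to 250000 nM), an estimated at least 1.6-fold lower number from compound 2 to compound 3 (0.22 log units; that floor lies within the scatter), with a fair chance that this assay again reports only a limit.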

Compound 3, half-maximal inhibitory concentration: > 100000 nM
Compound 3: a limit, no number (the forecaster's own chance of this, stated with the estimate: 40%); middle value at least 1.6-fold (0.22 log units) from the limit.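

In this assay compound 3 also gives only a limit, > 100000 nM. The change from the 2,4-dichlorophenyl amide reads as an at least 4.6-fold higher number from compound 1 to compound 3 (0.66 log units; beyond the scatter), so this loss on a carbonyl carbon also occurs with an aromatic ring of carbon only and does not require the ring nitrogen of compound 2. The step between compound 2 and compound 3 cannot be read, and no order can be given for the 2-chloropyridin-3-yl and 3-(methylsulfonyl)phenyl amides: the limit of > 100000 nM in this assay, at which 2 of the 3 values shown sit.

Still open, from the compounds shown here alone, is whether a phenyl ring with a single chlorine, as in a 4-chlorophenyl or 2-chlorophenyl amide, would keep a number in this assay. Also open, going by these compounds, is whether a group without an aromatic ring, such as cyclohexyl, would do so at this place.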